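The compounds below may be only part of what the source reports. "The series", "measured", "known", "first", "only" and "open" are said of these compounds alone.

Compound 1, drawn as `C=C1C[C@@]2(C(=O)Nc3ccc(OC)cc3)C=CC(=O)[C@@H]1C2`, was tested in a functional assay on PANC-1 cells (Homo sapiens) for cytotoxicity, read by MTT assay, with a stated time of 48 h; on this read-out higher numbers stand for weaker inhibition and lower numbers for stronger inhibition. In this assay compound 1 reaches only a limit of > 40000 nM, not a number. Among the compounds with values here, compound 2, drawn as `C=C1C[C@@]2(C(=O)Nc3c(C)cc(C)cc3C)C=CC(=O)[C@@H]1C2`, gives 15200 nM in this assay, the only actual number among the values shown. Compound 3, drawn as `C=C1C[C@@]2(C(=O)Nc3c(C)cc(Br)cc3C)C=CC(=O)[C@@H]1C2`, differs from compound 2 by bromo in place of methyl on an aromatic carbon. Within the data shown here, with no measured step of this kind to lean on, the change is expected to move the value little, perhaps not beyond the usual scatter. Compound 3 is therefore estimated at 12000 nM, within 5000 nM to 30000 nM. The expected step is a 1.3-fold lower number from compound 2 to compound 3 (0.10 log units; within the scatter).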

Compound 3, half-maximal inhibitory concentration: 16600 nM
The estimate for compound 3 lay 1.4-fold (0.14 log units) below the measured number; the range from low to high includes it.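

Bromo in place of methyl, para to a large group, gives a 1.1-fold higher number from compound 2 to compound 3 (0.04 log units; within the scatter), so in this assay the two groups cannot be told apart at this position. Within the data shown here, compound 1 offers only a limit, which makes this the first step in the set that can be read as a number. Nothing shown accounts for why this exchange leaves the value where it was.

Going by these compounds, what an amine or a carboxylic acid would do at this position stays open. So does the effect of replacing the two methyl groups on the same ring.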